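The source may report more compounds than this note shows. Statements on the series, on what has been measured and on what is new or still open speak of the compounds shown alone.

In an assay on VSM-A10 cells for antagonist activity at Endothelin-1 receptor (Rattus norvegicus) (on this read-out lower numbers stand for stronger inhibition and higher numbers for weaker inhibition), compound 1 `Cc1noc(NS(=O)(=O)c2cccc3c(N(C)C)cccc23)c1-c1ccccc1` gives 15900 nM, the lowest of the two numbers recorded so far. Compound 2 `Cc1noc(NS(=O)(=O)c2cccc3c(Cl)cccc23)c1C` gives 24000 nM in this assay, a value within the scatter of that of compound 1, so the two cannot be ranked. Compound 3 `CCOC(=O)c1c(C)noc1NS(=O)(=O)c1cccc2c(N(C)C)cccc12` differs from compound 1 in one place: ethoxycarbonyl in place of phenyl on an aromatic carbon. Within the data shown here, no measured pair shows a change of this kind, so the direction of the step is open. The step from compound 1 to compound 3 is expected to be a 1.3-fold lower number from compound 1 to compound 3 (0.12 log units; within the scatter), a small shift that may not exceed the scatter. Compound 3 is therefore expected to give about 12000 nM in this assay, within a range from 3000 nM to 50000 nM.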

Compound 3, half-maximal inhibitory concentration: 31000 nM
For compound 3 the middle estimate is 2.6-fold (0.41 log units) below the measured one; low and high end bracket the measured number.
By their numbers in this assay, from the lowest: compounds 1, 2 and 3 (each within the scatter of the next).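

Ethoxycarbonyl in place of phenyl on this aromatic carbon gives a 1.9-fold higher number from compound 1 to compound 3 (0.29 log units; within the scatter) in this assay, so this single pair does not separate the two groups. The position therefore takes a group with no ring and with hydrogen-bond acceptors without a shift beyond the scatter. No measurement at hand bears on why the two groups read alike. The compounds shown leave open whether an amine, a carboxylic acid or a longer chain on this carbon would move the number beyond the scatter.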